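This account rests on a few compounds, and the source may have more. Where it says the series, first, only, none or still open, it means among the compounds named here.

Compound 1 `CC(=O)Nc1nc(-c2cccc(NS(=O)(=O)c3cccc(Br)c3)c2)cs1` carries a bromo group on an aromatic carbon of its sulfonyl-bearing ring. In a functional assay on A-375 cells (Homo sapiens) for antiproliferative activity, read by trypan blue exclusion, with a stated time of 48 h, tested at 10 uM (a lower number here means a stronger effect, a higher number a weaker effect of the compound at the concentration tested), compound 1 gives 36%. Compound 2 `CC(=O)Nc1nc(-c2cccc(NS(=O)(=O)c3ccc(C#CCO)cc3)c2)cs1` is a relative with a different substituent pattern, and in this assay compound 2 gives 48.8%. Compound 3 `CCCCCCC#Cc1cccc(S(=O)(=O)Nc2cccc(-c3csc(NC(C)=O)n3)c2)c1` has oct-1-yn-1-yl in place of the bromo group. In this assay compound 3 gives < 1%, which is a limit of the assay rather than a number. That is the limit of < 1% in this assay, at which 1 of the 3 values shown sits. The change from bromo to oct-1-yn-1-yl produced a number at least 35 percentage points lower from compound 1 to compound 3 (beyond the scatter), so compound 3 sits at the limit and its exact value is not known.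

Compound 4 `CC(=O)Nc1nc(-c2cccc(NS(=O)(=O)c3cccc(C#C[Si](C)(C)C)c3)c2)cs1` is the next step from compound 3: a group of 4 heavy atoms (3 carbon, 1 silicon; no ring) in place of a group of 6 heavy atoms (6 carbon; no ring), on a triple-bonded carbon. The triple bond stays; only the group on its far end changes. Among the measured compounds shown here, the one measured step that bears on this, from compound 1 to compound 3, was large, but it introduced the whole alkyne chain, whereas here the chain is shortened and a silicon-bearing group put on. A modest weakening is therefore expected, with a real chance that compound 4 also reaches the limit. Compound 4 is expected to give 12%, within 1% to 35%. That corresponds to an expected step of a number at least 11 percentage points higher from compound 3 to compound 4 (beyond the scatter).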

Compound 4, a percentage reported as activity, at one concentration (the size of the read-out at that concentration, not a potency): 5.8%
The estimate for compound 4 lay 6.2 percentage points above the measured number; measured number inside the range.
By their numbers in this assay, from the lowest: compound 4; then compound 1; then compound 2. At a limit, below all of these: compound 3.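

In this assay, a triple bond carrying a silicon-bearing group also gives a large step against the bromo group, a number 30.2 percentage points lower from compound 1 to compound 4 (beyond the scatter). The low number on this aromatic carbon therefore does not require the hexyl group on the far end of the triple bond. Changing the hexyl group to the group of 4 heavy atoms (3 carbon, 1 silicon) gives a number at least 4.8 percentage points higher from compound 3 to compound 4 (that floor lies within the scatter), and compound 3 stands at a limit of the assay rather than at a number, so the true gap between these two end groups remains unknown: the limit of < 1% in this assay, at which 1 of the 4 values shown sits.

The compounds shown leave open whether the triple bond itself matters, and a plain octyl chain on the same aromatic carbon would test this directly. It also remains to be seen how much the far end of the triple bond can change, for instance with an amine, a carboxylic acid or a longer chain in place of the hexyl group.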